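Bromo in place of (pyridin-4-yl)sulfanyl on a shared core

The compounds below may be only part of what the source reports. "The series", "measured", "known", "first", "only" and "open" are said of these compounds alone.

Three compounds have been measured:
Compound 1 `Cc1c(N)cc2c(c1C)OC(C)(C)C2` gives 24.4 mg/kg in a functional assay on the whole organism with Mus musculus as the target; on this read-out lower numbers stand for an effect already at smaller amounts and higher numbers for an effect only at larger amounts of compound.
Compound 2 `Cc1c(C)c2c(c(C)c1N)CC(C)(CSc1ccncc1)O2` gives 19.9 mg/kg in this assay.
Compound 3 `Cc1c(C)c2c(c(C)c1N)CC(C)(CN1CCC(c3ccccc3)CC1)O2` gives 10.4 mg/kg in this assay.

On these numbers compound 2 stands second highest of the three. Its nearest neighbour is compound 1, whose number lies within the scatter of that of compound 2, and its furthest neighbour is compound 3, whose number also lies within the scatter. The three values are therefore not distinguished from one another, and nothing in them points to a direction in which a change at the saturated chain carbon moves the read-out.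

The next compound, compound 4 `Cc1c(C)c2c(c(C)c1N)CC(C)(CBr)O2`, has not yet been measured. It differs from compound 2 in one place: bromo in place of (pyridin-4-yl)sulfanyl on a saturated chain carbon bound to a saturated ring carbon. Among the measured compounds shown here, no measured pair shows what such a change does in this assay, so the expected size of the step rests only on the spread of the three values so far, which all lie within the scatter of each other. Compound 4 is therefore expected to land near its neighbours, with a step of a 1.1-fold higher number from compound 2 to compound 4 (0.04 log units; within the scatter) that is expected to stay within the scatter. The estimate for compound 4 is 22 mg/kg, with a range from 8 mg/kg to 60 mg/kg.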

Compound 4, dose for 50% inhibition: 16 mg/kg
The estimate for compound 4 lay 1.4-fold (0.14 log units) above the measured number, within the range that was stated.
By their numbers in this assay, from the lowest: compounds 3, 4, 2 and 1 (each within the scatter of the next, the first and the last beyond it).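

This pair gives the study its first direct reading of a single change on a saturated chain carbon bound to a saturated ring carbon: in this assay, replacing (pyridin-4-yl)sulfanyl with bromo gives a 1.2-fold lower number from compound 2 to compound 4 (0.09 log units; within the scatter). The group that leaves has 7 heavy atoms, a six-membered aromatic ring and 2 hydrogen-bond acceptors, while bromo has 1 heavy atom, no ring and no hydrogen-bond acceptors, yet the read-out does not separate compound 2 from compound 4. For this one pair, then, the aromatic ring and the sulfur of the departing group are not needed to keep the read-out within the scatter of that of compound 2, and no measurement shown here explains this result.

On these data alone, whether any group at this position can move the read-out beyond the scatter remains open, since this single step stays within it. A primary amine, a carboxylic acid or a longer alkyl chain on the same carbon would test whether this insensitivity extends beyond bromo and (pyridin-4-yl)sulfanyl.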